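Cytotoxicity notes: propoxy to dimethylamino on the shared core

This account rests on a few compounds, and the source may have more. Where it says the series, first, only, none or still open, it means among the compounds named here.

Compound 1 `CCCOc1cccc(-c2[nH]c3cc(OC)ccc3c(=O)c2C(=O)OCC)c1` in an ADME assay on BJ cells (Homo sapiens) for cytotoxicity, read by luminescence, with a stated time of 72 h (a lower number here means that less compound is needed, a higher number that more compound is needed for the effect), gives only a limit, > 21500 nM. Compound 2 `CCOC(=O)c1c(-c2cccc(F)c2)[nH]c2cc(OC)ccc2c1=O` likewise gives only a limit in this assay, > 21500 nM. Among the measured compounds shown here, the single measured step, a step that the two limits leave unreadable from compound 1 to compound 2, thus has no readable size; both values sit at the limit of > 21500 nM in this assay, at which 2 of the 2 values shown sit. Compound 3 `CCOC(=O)c1c(-c2cccc(N(C)C)c2)[nH]c2cc(OC)ccc2c1=O` differs from compound 1 by dimethylamino in place of propoxy on an aromatic carbon. With no readable step and both measured compounds at the limit, no step beyond the scatter is expected in this assay in either direction, and a further limit is the likely outcome. Compound 3 is expected at 30000 nM, range 15000 nM to 100000 nM. The expected step is then a step that the limit leaves unreadable from compound 1 to compound 3.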

Compound 3, half-maximal effective concentration: > 21500 nM
Compound 3: no number, only a limit; the forecaster's own chance of this, stated with the estimate: 85%; the middle value is on the limit's open side.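

In this assay compound 3 gives only the limit > 21500 nM and no step from compound 1 or compound 2 to compound 3 can be read: the limit of > 21500 nM in this assay, at which 3 of the 3 values shown sit.

Whether any group at this aromatic carbon gives a readable number in this assay stays open in the compounds shown.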